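Swapping the Alkyne Substituent from Cyclohexyl to Silicon

This account rests on a few compounds, and the source may have more. Where it says the series, first, only, none or still open, it means among the compounds named here.

Three compounds sharing one core have been examined in a functional assay on A-375 cells (Homo sapiens) for antiproliferative activity, read by trypan blue exclusion, with a stated time of 48 h, tested at 1 uM; a higher number here means a weaker effect of the compound at the concentration tested, a lower number a stronger effect. Compound 1 `CC(=O)Nc1nc(-c2cccc(NS(=O)(=O)c3ccc(Br)cc3)c2)cs1` carries bromine at the end of the sulfonamide ring and gives "not active" (no number reported), with no number given. Compound 2 `CC(=O)Nc1nc(-c2cccc(NS(=O)(=O)c3ccc(C#CCO)cc3)c2)cs1` gives 81.3% in this assay, while compound 3 `CC(=O)Nc1nc(-c2cccc(NS(=O)(=O)c3ccc(C#CC4CCCCC4)cc3)c2)cs1` gives 52.3%. Going by the values given here, compound 3 thus stands as the lowest of the two numbers, and the one move between the two, a number 29 percentage points lower from compound 2 to compound 3 (beyond the scatter), is the only measured step that touches the group on the triple-bonded carbon.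

Compound 4 `CC(=O)Nc1nc(-c2cccc(NS(=O)(=O)c3ccc(C#C[Si](C)(C)C)cc3)c2)cs1` differs from compound 3 in exactly that place: a group of 4 heavy atoms (3 carbon, 1 silicon; no ring) in place of a group of 6 heavy atoms (6 carbon; one six-membered non-aromatic ring of carbon only), on a triple-bonded carbon. Among the compounds with values here, the only step that bears on this change is the one from hydroxymethyl to cyclohexyl, which was modest and moved the number down. The new group is neither of those, and nothing measured shows how a silicon-containing group behaves here. Within the data shown here, compound 4 is therefore expected to lie between the two known numbers, closer to compound 3, so the expected step of a number 12.7 percentage points higher from compound 3 to compound 4 (beyond the scatter) is small and upward. The estimate for compound 4 in this assay is 65%, with a range from 45% to 88%.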

Compound 4, a percentage reported as activity, at one concentration (the size of the read-out at that concentration, not a potency): 94.3%
For compound 4 the middle estimate is 29.3 percentage points below the measured one; measured number above the stated range.
By their numbers in this assay, from the lowest: compound 3; then compound 2; then compound 4.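

In this assay, the new group brings a number 42 percentage points higher from compound 3 to compound 4 (beyond the scatter), which shows that a change on this triple-bonded carbon can produce a large swing and that the low number of compound 3 does not carry over to every uncharged group without hydrogen-bond donors or acceptors. The second comparison gives a number 13 percentage points higher from compound 2 to compound 4 (beyond the scatter), so among these three compounds the number does not follow heavy-atom count: the group of 4 heavy atoms gives the weakest effect of the three, above both the group of 2 and cyclohexyl with its 6. No available evidence accounts for the difference between the silicon-containing group and cyclohexyl.

The compounds shown do not separate the role of silicon from that of the overall group shape, a question that tert-butyl, an all-carbon group, could address. They also leave open whether the ring of cyclohexyl matters, or whether a cyclopentyl ring or a longer unbranched carbon chain on the same triple-bonded carbon would give a number as low as that of compound 3.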